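The compounds below may be only part of what the source reports. "The series", "measured", "known", "first", "only" and "open" are said of these compounds alone.

Compound 1, `NC1=NC2(CCOCC2)N(OCCCOc2ccc(Cl)cc2)C(N)=N1`, was tested in an assay on isolated protein for inhibition of Dihydrofolate reductase (Homo sapiens), read by spectrophotometry, using NADPH, with stated times of 5 s and 6 min, tested at 5 uM; a lower number here means a weaker effect, a higher number a stronger effect of the compound at the concentration tested. For compound 1 the result reported there is > 90%, which is a limit of the assay and not a number. Compound 2, `NC1=NC2(CCOCC2)N(OCCCOc2ccccc2Cl)C(N)=N1`, gives 83.3% in this assay. For the measured compounds named here, the single measured step, a number at least 6.7 percentage points lower from compound 1 to compound 2 (that floor lies within the scatter), is the only comparison available. Going by the values given here, compound 2 therefore holds the only plain number in this set, because the limit of > 90% in this assay, at which 1 of the 2 values shown sits, covers the other entry.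

Compound 3, `NC1=NC2(CCOCC2)N(OCCCOc2ccc(Cl)cc2Cl)C(N)=N1`, differs from compound 2 by chloro in place of hydrogen on an aromatic carbon. Among the compounds with values here, no measured step here puts a chloro group where a hydrogen stood; the one step measured, a move of a chloro group, stayed within the scatter. The change is therefore expected to give a number 4.7 percentage points higher from compound 2 to compound 3 (within the scatter), nothing beyond the usual scatter. For compound 3 a value of 88% is estimated, with a range from 72% to 96%.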

Compound 3, a percentage reported as inhibition, at one concentration (the size of the read-out at that concentration, not a potency): > 90%
Compound 3 gave a limit, no number; the forecaster's own chance of this, stated with the estimate: 35%; middle value at least 2 percentage points away from the limit.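

Putting chloro in place of hydrogen on the aromatic carbon para to the large group, meta to the chloro group already there, gives a number at least 6.7 percentage points higher from compound 2 to compound 3 (that floor lies within the scatter) and so adds no reading beyond the usual scatter. In this assay compound 3 gives > 90% as a limit of the assay and not a number, which shows that a ring carrying this second chloro group still reaches the top reported level. The steps that end at compound 3 from compound 1 cannot be read, and these compounds cannot be ranked at that level, because the values stop at one limit: the limit of > 90% in this assay, at which 2 of the 3 values shown sit.

Going by these compounds, whether a methoxy group, an amine or a carboxylic acid at this place would hold the read-out at that level remains open. A read-out at one concentration gives no potency, so any true difference made by the second chloro group is also unresolved.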